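A hydroxy group on the saturated ring of compound 2

A few compounds are considered here, and "the series" means these few. Any claim that something is new, unique, unknown or untested is made for them only; others in the source may bear on it.

In an ADME assay on a cell-free system (plasma, Homo sapiens) for protein binding, read by LC-MS, using equilibrium dialysis, with a stated time of 4 h (a lower number here means a smaller unbound share, a higher number a larger unbound share of the compound), compound 2 `Cn1ccc(-c2ccc(Cc3cc(C(=O)NC4CCOCC4)nc4c3ccn4C)cc2)n1` gives 0.02 and sits level with compound 1 `Cn1ccc2c(Cc3ccc(-c4nccs4)cc3)cc(C(=O)N[C@@H]3CCOC[C@H]3O)nc21` at 0.02 within the scatter. Compound 3 `Cn1ccc(-c2ccc(Cc3cc(C(=O)N[C@@H]4CCOC[C@H]4O)nc4c3ccn4C)cc2)n1` differs from compound 2 in one place (hydroxy in place of hydrogen on a saturated ring carbon), with hydroxy in place of hydrogen on a saturated ring carbon, so that (oxan-4-yl)carbamoyl becomes (3-hydroxyoxan-4-yl)carbamoyl. Going by the values given here, no measured pair shows this change alone. Compound 1 already bears the (3-hydroxyoxan-4-yl)carbamoyl group, differs elsewhere, and reads 0.02 in this assay as well. A small rise in the unbound share is therefore expected, with nothing beyond the scatter, and the estimated change (a 1.5-fold higher number from compound 2 to compound 3 (0.18 log units; within the scatter)) stays modest. For compound 3 the estimated unbound fraction is 0.03 with an expected range of roughly (0.015 to 0.05).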

Compound 3, unbound fraction: 0.02
Compound 3: the middle estimate sits 1.5-fold (0.18 log units) above what was measured; the measured number falls inside the stated range.
By their numbers in this assay, from the lowest: compounds 1, 2 and 3 (each within the scatter of the next).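

Going by these compounds alone, with hydroxy in place of hydrogen on a saturated ring carbon, this assay shows no change at the digits printed from compound 2 to compound 3 (within the scatter) and thus gives this position its first direct reading, as the earlier compounds offered no pair with this change alone. With 1-methyl-1H-pyrazol-3-yl in place of 1,3-thiazol-2-yl on an aromatic carbon, the same assay shows no change at the digits printed from compound 1 to compound 3 (within the scatter) and so, with the (3-hydroxyoxan-4-yl)carbamoyl group held in place, this aromatic change also leaves the reading level. Nothing available explains either result.

The compounds shown leave open whether an amine, a carboxylic acid or a methoxy group at this ring carbon would read differently from hydroxy. They also leave open whether the hydroxy group would read the same with the opposite arrangement at the two ring carbons, or on another core.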